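The source may hold more compounds than are shown below. What is called first, only, known or untested is meant among the compounds shown, and "the series" means these compounds.

Working notes on the series. In a functional assay on cells (T-cell, Homo sapiens) for inhibition (a lower number here means a stronger inhibitor, a higher number a weaker inhibitor), compound 1 `COc1ccc(-c2cnc3nc(N)nc(N4CCN(c5cc(Cl)cc(Cl)c5)CC4)c3n2)cc1OC` gives 3400 nM, the highest of the two numbers in hand. Compound 3 `COc1ccc(-c2cnc3nc(N)nc(NC4CCCC4)c3n2)cc1OC` gives 800 nM, a lower number than compound 1 by more than the usual scatter. Compound 2 `CC(C)Oc1nc(N)nc2ncc(-c3ccc(C(F)(F)F)cc3)nc12` reaches only the limit of this assay, > 10000 nM; (the limit of > 10000 nM in this assay, at which 1 of the 3 values shown sits). Compound 4 `COc1ccc(-c2cnc3nc(N)nc(N4CCN(C(=O)Nc5ccc(F)cc5)CC4)c3n2)cc1OC` has not yet been measured in this assay. Relative to compound 1 it carries (4-fluorophenyl)carbamoyl in place of 3,5-dichlorophenyl on an amine nitrogen in a ring. Among the measured compounds shown here, no measured pair in this set isolates such a change, so the direction is open. The step of a 1.4-fold lower number from compound 1 to compound 4 (0.13 log units; within the scatter) is expected to be modest, within the scatter or slightly downward. Compound 4 is therefore estimated at 2500 nM, with a range from 600 nM to 10000 nM.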

Compound 4, half-maximal inhibitory concentration: 7 nM
Compound 4: the middle estimate sits 360-fold (2.55 log units) above what was measured; measured number below the stated range.
By their numbers in this assay, from the lowest: compound 4; then compound 3; then compound 1. At a limit, above all of these: compound 2.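

In this assay, the amine nitrogen in the ring proves a highly sensitive position: placing (4-fluorophenyl)carbamoyl there in place of 3,5-dichlorophenyl gives a 490-fold lower number from compound 1 to compound 4 (2.69 log units; beyond the scatter). The earlier compounds shown here offered no pair that isolated a change at this position. The change brings in a carbonyl, a hydrogen-bond donor and a hydrogen-bond acceptor together, and nothing at hand accounts for the size of the step.

The compounds shown do not separate the contribution of the carbamoyl link from that of the fluorine. An unsubstituted phenylcarbamoyl or an acetyl group on the same nitrogen would help to tell them apart.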